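From cyclohexyl to phenethyl on a sulfur-bound chain

The compounds below may be only part of what the source reports. "The series", "measured", "known", "first", "only" and "open" are said of these compounds alone.

Values measured so far in a functional assay on PC-9 cells (Homo sapiens) for inhibition, read by MTT assay, with a stated time of 72 h (a higher number here means a weaker inhibitor, a lower number a stronger inhibitor), are these:

Compound 1 `Cc1cc(Nc2cc(-c3cccs3)[nH]n2)n2nc(SCc3ccc(Br)cc3)nc2n1` gives 4890 nM as a number
Compound 2 `Cc1cc(Nc2cc(-c3ccccc3)[nH]n2)n2nc(SCC3CCCCC3)nc2n1` gives > 50000 nM as a limit
Compound 3 `CCCCCc1c(C)nc2nc(SCc3ccc(Cl)cc3)nn2c1Nc1cc(-c2ccccc2)[nH]n1` gives > 50000 nM as a limit

Compound 2 stands at the limit of > 50000 nM in this assay, at which 2 of the 3 values shown sit, and this is a limit, not a number. Its true place on the scale is therefore open, and any step away from it can only be judged loosely. Among the measured compounds shown here, compound 1 gives 4890 nM as the only true number in the set.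

Compound 4 `Cc1cc(Nc2cc(-c3ccccc3)[nH]n2)n2nc(SCCCc3ccccc3)nc2n1` is the next to be read in this assay and keeps the rest of compound 2 unchanged. The change phenethyl in place of cyclohexyl on a saturated chain carbon bound to a sulfur puts phenethyl in place of cyclohexyl on a saturated chain carbon bound to a sulfur. No measured pair sizes such a change, so the expectation is a rough one. For the measured compounds named here, a modest move toward a stronger reading is expected, with compound 1 at 4890 nM as the only guide to how far the numbers reach. A step of an at least 1.6-fold lower number from compound 2 to compound 4 (0.22 log units; that floor lies within the scatter) is the expected size in this assay and a reading at the limit remains quite possible. For compound 4 the estimate is 30000 nM with an expected range from 8000 nM to 50000 nM in this assay.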

Compound 4, half-maximal inhibitory concentration: 5030 nM
For compound 4 the middle estimate is 6.0-fold (0.78 log units) above the measured one; measured number below the stated range.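

In this assay, among the compounds shown here, the change of cyclohexyl to phenethyl on a saturated chain carbon bound to a sulfur gives an at least 9.9-fold lower number from compound 2 to compound 4 (0.99 log units; beyond the scatter) and so shows what the earlier compounds, with no measured pair among them, could not: the reading in this assay responds to the group at this place. Cut one bond further out, the same change is cyclohexylmethyl to 3-phenylpropyl, which replaces a six-membered non-aromatic ring with a six-membered aromatic one and brings no hydrogen-bond donors or acceptors on either side. The step gives only a floor, and its full size stays unknown because compound 2 stands at a limit and not at a number: the limit of > 50000 nM in this assay, at which 2 of the 4 values shown sit.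

This single pair changes the ring and the length of the chain at once, and it leaves open which of the two carries the step. Also open, as far as these compounds go, is how this place would read with an amine or a carboxylic acid at the end of the chain, or with a chain longer than 3-phenylpropyl.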